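A few compounds are considered here, and "the series" means these few. Any claim that something is new, unique, unknown or untested is made for them only; others in the source may bear on it.

Measured so far in a functional assay on CHO cells for agonist activity at Free fatty acid receptor 1 (Homo sapiens); a lower number here means that less compound is needed, a higher number that more compound is needed for the effect:
compound 1 `O=C(O)/C=C/c1ccc(NCc2cccc(Oc3ccccc3)c2)cc1` — 145 nM
compound 2 `Cc1nc(-c2ccc(C(F)(F)F)cc2)sc1CNc1ccc(CC(C)C(=O)O)cc1` — 355 nM

Compound 1 stands at the lowest number of the two. Compound 2 gives 355 nM, a higher number than compound 1, and the gap between the two lies beyond the usual scatter of this assay. Within the data shown here, no pair of compounds differing in one place has been measured, so no step size from is available; the two compounds differ in several places at once.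

Compound 3 `CNC(=O)CCc1ccc(NCc2cccc(Oc3ccccc3)c2)cc1` is the next compound to be measured. Relative to compound 1 the change is 2-(methylcarbamoyl)ethyl in place of 2-carboxyethenyl on an aromatic carbon. Among the measured compounds shown here, the compound 1 value of 145 nM is the only anchor for this step. For the measured compounds named here, with no measured step to rest on, the expectation is for a move to a clearly higher number, beyond the scatter, rather than no change. Compound 3 is expected to give 3000 nM, with a range from 700 nM to 15000 nM. The step this estimate means is a 21-fold higher number from compound 1 to compound 3 (1.32 log units; beyond the scatter).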

Compound 3, half-maximal effective concentration: 49 nM
Estimate against measurement, compound 3: 61-fold (1.79 log units) above, and the stated range ends above it.
By their numbers in this assay, from the lowest: compound 3; then compound 1; then compound 2.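

At the aromatic carbon para to a large group, in this assay, putting 2-(methylcarbamoyl)ethyl in place of 2-carboxyethenyl gives a 3.0-fold lower number from compound 1 to compound 3 (0.47 log units; beyond the scatter), a modest step in the direction of less compound needed. Among these compounds, the core of compound 1 therefore does not depend on a carboxylic acid at this place to reach a number of this order: compound 3 carries a methyl amide there and still gives 49 nM, the lowest number among the compounds so far. The change is a composite one, replacing the acid with the methyl amide and the chain's carbon-carbon double bond with a saturated chain, and no measurement on hand explains the direction or the size of the step.

Among the compounds shown here, the single step cannot divide its effect between the saturated chain and the methyl amide; a 2-carboxyethyl group at the same place would separate the two. Also open, going by these compounds, is how this place responds to a primary amide, a dimethyl amide or a longer chain, and whether the methyl amide gives a similar step on the core of compound 2.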